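Methylation of the sulfonamide nitrogen in compound 1

This account rests on a few compounds, and the source may have more. Where it says the series, first, only, none or still open, it means among the compounds named here.

Measured compounds in an assay on SK-BR-3 cells for inhibition of Aromatase (Homo sapiens); on this read-out lower numbers stand for stronger inhibition and higher numbers for weaker inhibition:
compound 1 `CCCOc1cc([N+](=O)[O-])ccc1NS(C)(=O)=O`, 2510 nM
compound 2 `CS(=O)(=O)Nc1ccc([N+](=O)[O-])cc1OCC1CCCCC1`, 1210 nM
compound 3 `CCCCCCCCCOc1cc([N+](=O)[O-])ccc1NS(C)(=O)=O`, 910 nM

Compound 1 carries the highest number of the three in this assay. Its nearest neighbour is compound 2 , reached by a 2.1-fold lower number from compound 1 to compound 2 (0.32 log units; beyond the scatter), and the furthest is compound 3 , reached by a 2.8-fold lower number from compound 1 to compound 3 (0.44 log units; beyond the scatter). Between compound 2 and compound 3 the step is a 1.3-fold lower number from compound 2 to compound 3 (0.12 log units; within the scatter). All three measured steps concern only the chain attached to the ether oxygen on the aromatic ring; the sulfonamide part is identical in every measured compound.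

Compound 4 `CCCOc1cc([N+](=O)[O-])ccc1N(C)S(C)(=O)=O` differs from compound 1 by methyl in place of hydrogen on a sulfonamide nitrogen. For the measured compounds named here, no measured step touches this position, so the series gives no direct guidance on the size or direction of the change. The ether-chain steps show that the core tolerates modest variation without large swings, but they say nothing about the sulfonamide nitrogen itself. With nothing to argue for a shift, compound 4 is expected to stay close to compound 1, with the step of a 1.0-fold lower number from compound 1 to compound 4 (0.00 log units; within the scatter) expected to lie within the scatter. The estimate for compound 4 is 2500 nM, with a wide range from 800 nM to 8000 nM reflecting the absence of any bearing step.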

Compound 4, half-maximal inhibitory concentration: 760 nM
Beside the measured number, compound 4's estimate is 3.3-fold (0.52 log units) above it; measured number below the stated range.
By their numbers in this assay, from the lowest: compounds 4, 3 and 2 (each within the scatter of the next); then compound 1.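

The sulfonamide nitrogen is a position where a small change registers: in this assay, methyl in place of hydrogen, an addition of one carbon, gives a 3.3-fold lower number from compound 1 to compound 4 (0.52 log units; beyond the scatter), while the ether-chain changes had left this position unexplored. With the propyl ether of compound 1 held constant, the hydrogen on the sulfonamide nitrogen is therefore not needed to keep the number low, and the methylated nitrogen gives the lower number of the pair, a modest step of the same direction as the hexyl extension on the ether chain, a 2.8-fold lower number from compound 1 to compound 3 (0.44 log units; beyond the scatter). No available evidence bears on what lies behind this step.

Still open, going by these compounds, is whether an ethyl group, a longer chain or a carboxylic acid-bearing chain on the sulfonamide nitrogen would continue this step, hold it or reverse it. On these data alone, it is equally open whether methyl on that nitrogen would lower the number in the same way when the ether carries the cyclohexyl or octyl groups of compound 2 and compound 3, since the two changes have not been seen together in one compound here.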